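Trimethoxyphenyl for methoxyphenyl on the dimethyl-benzothiazole amide

The source may hold more compounds than are shown below. What is called first, only, known or untested is meant among the compounds shown, and "the series" means these compounds.

Measured so far in a functional assay on HeLa cells (Homo sapiens) for cytotoxicity, read by MTT assay, with a stated time of 48 h; a higher number here means a weaker inhibitor, a lower number a stronger inhibitor:
compound 1 `COc1cc(-c2cc(C(=O)Nc3nc4ccc(Cl)cc4s3)nc3cc(-c4ccccc4)nn23)cc(OC)c1OC` gives 22400 nM;
compound 2 `COc1cc(-c2cc(C(=O)Nc3nc4ccc(F)cc4s3)nc3cc(-c4ccccc4)nn23)cc(OC)c1OC` gives 25100 nM;
compound 3 `COc1ccc(-c2cc(C(=O)Nc3nc4cc(C)c(C)cc4s3)nc3cc(-c4ccccc4)nn23)cc1` gives 14100 nM.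

Compound 3 stands at one end of these numbers, yet its gaps to compound 1 and compound 2 both fall within the scatter, so the three are indistinguishable on this assay.

Compound 4 `COc1cc(-c2cc(C(=O)Nc3nc4cc(C)c(C)cc4s3)nc3cc(-c4ccccc4)nn23)cc(OC)c1OC` differs from compound 3 by 3,4,5-trimethoxyphenyl in place of 4-methoxyphenyl on an aromatic carbon. No measured step covers this change: the only step shown, a 1.1-fold higher number from compound 1 to compound 2 (0.05 log units; within the scatter), concerns the halogen on the other end of the shared core and stays within the scatter. Compound 1 and compound 2 already carry the trimethoxyphenyl group and give numbers near compound 3. No change beyond the scatter is therefore expected in this assay, and the expected step is a 1.3-fold higher number from compound 3 to compound 4 (0.11 log units; within the scatter).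

For compound 4 the estimate in this assay is 18000 nM, with a range from 8000 nM to 45000 nM.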

Compound 4, half-maximal inhibitory concentration: 8910 nM
The estimate for compound 4 lay 2.0-fold (0.31 log units) above the measured number, within the range that was stated.
By their numbers in this assay, from the lowest: compounds 4, 3, 1 and 2 (each within the scatter of the next, the first and the last beyond it).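

In this assay, 3,4,5-trimethoxyphenyl in place of 4-methoxyphenyl gives a 1.6-fold lower number from compound 3 to compound 4 (0.20 log units; within the scatter) and so shows no clear change at this position. Within the data shown here, with the trimethoxyphenyl group held constant, 5,6-dimethyl-1,3-benzothiazol-2-yl in place of 6-fluoro-1,3-benzothiazol-2-yl gives a 2.8-fold lower number from compound 2 to compound 4 (0.45 log units; beyond the scatter) and in place of 6-chloro-1,3-benzothiazol-2-yl gives a 2.5-fold lower number from compound 1 to compound 4 (0.40 log units; beyond the scatter) as the first steps beyond the scatter, both at the amide nitrogen. No supporting data bear on the origin of these steps.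

From the compounds shown here alone, how an amine or a carboxylic acid would read in place of the aryl group remains open. The same applies to a longer chain in place of the two methyl groups on the benzothiazole.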